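Methyl to methoxy on the aryl ring of a thiazole hydrazone

The compounds below may be only part of what the source reports. "The series", "measured", "known", "first", "only" and "open" are said of these compounds alone.

Compound 1 `COc1ccc(-c2csc(N/N=C/c3ccc(-n4ccnc4)cc3)n2)cc1`: 26.8%
Compound 2 `Clc1ccc(-c2csc(N/N=C/c3ccc(-n4cncn4)cc3)n2)cc1`: 28.4%
Compound 3 `Cc1ccc(-c2csc(N/N=C/c3ccc(-n4cncn4)cc3)n2)cc1`: 13.6%

In an ADME assay on THP-1 cells (Homo sapiens) for cytotoxicity, read by MTT assay, tested at 50 ug/mL (a higher number here means more inhibition at the concentration tested (going by the name of the read-out), a lower number less inhibition), compound 3 gives the lowest of the three numbers, with compound 1 standing higher by a margin beyond the scatter. Going by the values given here, the one measured step, a number 14.8 percentage points lower from compound 2 to compound 3 (beyond the scatter), bears only indirectly, since it concerns a different substituent at the same position. Compound 4 `COc1ccc(-c2csc(N/N=C/c3ccc(-n4cncn4)cc3)n2)cc1` differs from compound 3 in one place: methoxy in place of methyl on an aromatic carbon. Among the compounds with values here, no measured pair shows this exact exchange; compound 1, which also carries a methoxy group, gives 26.8%, but with a different heteroaryl ring elsewhere. Compound 4 is therefore expected to rise by a number 9.4 percentage points higher from compound 3 to compound 4 (within the scatter), to an estimated 23%, within 12% to 34%.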

Compound 4, a percentage reported as inhibition, at one concentration (the size of the read-out at that concentration, not a potency): 23%
Estimate against measurement, compound 4: no gap at the digits printed; measured number inside the range.
By their numbers in this assay, from the lowest: compounds 3, 4, 1 and 2 (each within the scatter of the next, the first and the last beyond it).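

In this assay the exchange at this aromatic carbon gives a number 9.4 percentage points higher from compound 3 to compound 4 (within the scatter) and, against chloro, a number 5.4 percentage points lower from compound 2 to compound 4 (within the scatter), so methoxy is not separated from either group, even though the earlier step separated chloro from methyl. The other change, read with methoxy in place, gives a number 3.8 percentage points lower from compound 1 to compound 4 (within the scatter) and so leaves the number within the scatter. Nothing measured here accounts for these steps.

Going by these compounds, whether an amine, a hydroxyl or a longer chain on this carbon would move the number stays open. So does whether the 1H-1,2,4-triazol-1-yl for 1H-imidazol-1-yl exchange reads the same with chloro or methyl.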